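This account rests on a few compounds, and the source may have more. Where it says the series, first, only, none or still open, it means among the compounds named here.

Working notes on the series. In a functional assay on Jurkat cells (Homo sapiens) for activation, with a stated time of 24 h (a lower number here means that less compound is needed, a higher number that more compound is needed for the effect), compound 1 `O=[N+]([O-])c1ccc(NCc2ccccc2O)cc1` gives "not active" (no number reported). Compound 2 `Oc1ccccc1CNc1ccc(N2CCNCC2)cc1` likewise gives "not active" (no number reported) in this assay. Going by the values given here, compound 3 `Oc1ccccc1CNc1ccc(-c2ccc(F)cc2)cc1` gives 3860 nM in this assay, and compound 3 therefore stands as the only entry with a number, the other two entries having no single value. Compound 4 `CC(C)(C)c1ccc(-c2ccc(NCc3ccccc3O)cc2)cc1` differs from compound 3 by tert-butyl in place of fluoro on an aromatic carbon. Among the compounds with values here, no step between two measured compounds is available, so the size of this change cannot be read from the series itself. The step from compound 3 to compound 4 is expected to stay within the usual scatter, a 1.3-fold lower number from compound 3 to compound 4 (0.11 log units; within the scatter). For compound 4 the estimate in this assay is 3000 nM, with a range from 800 nM to 12000 nM.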

Compound 4, half-maximal effective concentration: "not active" (no number reported)
Nothing numeric was reported for compound 4; the estimate stays without a comparison.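

Going by these compounds alone, compound 4 carries no number in this assay, so no step from compound 3 to compound 4 can be read. No supporting data bear on this result. The compounds shown leave open how tert-butyl in place of fluoro alters the response.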